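Swapping Pyrrolidin-1-yl for Dimethylamino on a Second Core

The compounds below may be only part of what the source reports. "The series", "measured", "known", "first", "only" and "open" are said of these compounds alone.

Measured so far:
Compound 1 `COc1ccc2[nH]c([S+]([O-])Cc3nccc(N4CCCC4)c3Cl)nc2c1` gives 36 h in an ADME assay for pharmacokinetics, at pH 7.4; a lower number here means that the compound disappears faster, a higher number that the compound lasts longer.
Compound 2 `COc1ccc2[nH]c([S+]([O-])Cc3nccc(N(C)C)c3Cl)nc2c1` gives 17 h in this assay.
Compound 3 `COc1ccc2[nH]c([S+]([O-])Cc3cc(N4CCCC4)c(Br)cn3)nc2c1` gives 49 h in this assay.

The change from compound 1 to compound 2 is dimethylamino in place of pyrrolidin-1-yl on an aromatic carbon, and it produced a 2.1-fold lower number from compound 1 to compound 2 (0.33 log units; beyond the scatter). Compound 4 `COc1ccc2[nH]c([S+]([O-])Cc3cc(N(C)C)c(Br)cn3)nc2c1` is made from compound 3 by the same kind of change, (dimethylamino in place of pyrrolidin-1-yl on an aromatic carbon); the surroundings differ in that the group sits ortho to a bromo group here rather than ortho to a chloro group. How the core of compound 3 differs from that of compound 1 is not broken down here. For compound 4 a step of a 2.1-fold lower number from compound 3 to compound 4 (0.33 log units; beyond the scatter) in this assay is expected, resting on the size of a 2.1-fold lower number from compound 1 to compound 2 (0.33 log units; beyond the scatter) applied to compound 3 with 49 h. Compound 4 is therefore estimated at 23 h, expected to lie between 12 h and 45 h.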

Compound 4, half-life in the ADME assay: 101 h
Compound 4: the middle estimate sits 4.4-fold (0.64 log units) below what was measured; the measured number lies above the stated range.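

In the ADME assay, placing dimethylamino where pyrrolidin-1-yl stood gave a 2.1-fold higher number from compound 3 to compound 4 (0.31 log units; beyond the scatter), so the direction of the step did not carry over from one core to the other: the same change on two cores in the ADME assay, a 2.1-fold lower number (0.33 log units; beyond the scatter) from compound 1 to compound 2 and a 2.1-fold higher number (0.31 log units; beyond the scatter) from compound 3 to compound 4, 4.4-fold (0.64 log units) apart, beyond the scatter of two such steps

In a physicochemical assay for acid dissociation, compound 3 gives 6.92 and compound 4 gives 5.8. In the physicochemical assay, the same change on this core also moved the number: the measured acid dissociation constant of compound 3, 6.92, and of compound 4, 5.8, a number 1.12 log units lower (beyond the scatter)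

A step measured on one core is therefore a poor guide to the same change on another core in this series, but a single pair on each core does not show why the direction differs, or whether this second shift has any link to the first.

Going by these compounds, it remains open whether the direction follows the bromo or chloro group or some other part of the core. On these data alone, it is also open how another amine, such as diethylamino, would behave on each core.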